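Swapping Methoxy for Trifluoromethyl on a Shared Core

The source may hold more compounds than are shown below. What is called first, only, known or untested is meant among the compounds shown, and "the series" means these compounds.

Of the compounds shown here, three have so far been measured in an assay on isolated protein for inhibition of 15-hydroxyprostaglandin dehydrogenase [NAD(+)] (Homo sapiens), read by fluorescence, with a stated time of 15 min; a lower number here means a stronger inhibitor, a higher number a weaker inhibitor. Compound 1 `Cc1ccc(-n2c(C)cc(-c3nnc4n3CCCCC4)c2C)cc1` gives 34 nM. Compound 2 `O=C(c1ccc2c(c1)ncn2-c1ccccc1)N1CCCCC1` gives 22 nM, and compound 3 `COc1cccc(-n2cnc3cc(C(=O)N4CCCCC4)ccc32)c1` gives 19 nM. Compound 3 therefore sits alongside compound 2 and compound 1, all three within the usual scatter of one another, so none of them can be called stronger or weaker on these numbers. Going by the values given here, the single measured step that changes one place, a 1.2-fold lower number from compound 2 to compound 3 (0.06 log units; within the scatter), adds a methoxy group to the aromatic ring of compound 2 and leaves the number essentially where it was.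

Compound 4 `O=C(c1ccc2c(c1)ncn2-c1cccc(C(F)(F)F)c1)N1CCCCC1` has not yet been measured. It differs from compound 3 by trifluoromethyl in place of methoxy on an aromatic carbon; the group sits on an aromatic carbon of a six-membered aromatic ring of carbon only, meta to a large group. Among the compounds with values here, the only step that bears on this spot, from compound 2 to compound 3, shows that hydrogen and methoxy there give numbers within the scatter, so this position has so far tolerated a change without a shift in the result. With nothing more to go on, no step beyond the scatter is expected for compound 4 in this assay, which means an estimated 1.2-fold higher number from compound 3 to compound 4 (0.06 log units; within the scatter). Compound 4 is therefore expected to give about 22 nM, with a likely range from 8 nM to 60 nM.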

Compound 4, half-maximal inhibitory concentration: 48 nM
Compound 4: the middle estimate sits 2.2-fold (0.34 log units) below what was measured; low and high end bracket the measured number.
By their numbers in this assay, from the lowest: compounds 3, 2, 1 and 4 (each within the scatter of the next, the first and the last beyond it).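

In this assay, going by these compounds alone, trifluoromethyl on this aromatic carbon gives a 2.5-fold higher number from compound 3 to compound 4 (0.40 log units; beyond the scatter) and also a 2.2-fold higher number from compound 2 to compound 4 (0.34 log units; beyond the scatter) so a change at this position now moves the number beyond the scatter for the first time, though only modestly. Hydrogen and methoxy had stayed within the scatter of each other, so the new result shows that this position does not treat every group alike, and that trifluoromethyl shifts the number towards a weaker inhibitor than either of them. Nothing measured here explains why this shift occurs.

Only three groups are shown on this carbon, so it remains open whether the shift is particular to trifluoromethyl or would also appear with a chlorine atom, an amine or a carboxylic acid in the same place. Going by these compounds, it is also open whether swapping methoxy for trifluoromethyl would shift the number in the same way on a different core, such as the core of compound 1.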